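The source may hold more compounds than are shown below. What is called first, only, known or untested is meant among the compounds shown, and "the series" means these compounds.

Working notes on the series. For the measured compounds named here, compound 3 `O=C(/C=C/c1ccc(O)c(O)c1)c1cc(O)ccc1O` gives in an assay on RBL-1 cells for inhibition of Polyunsaturated fatty acid 5-lipoxygenase (Rattus norvegicus) (a higher number here means a weaker inhibitor, a lower number a stronger inhibitor), a value of 64 nM, the highest of the three numbers measured so far; compound 2 `O=C(/C=C/c1ccc(O)c(O)c1)c1ccc([N+](=O)[O-])cc1` gives 23 nM and compound 1 `O=C(/C=C/c1ccc(O)c(O)c1)c1cccc(O)c1` gives 4.2 nM. Compound 4 `CC(C)c1ccc(O)c(C(=O)/C=C/c2ccc(O)c(O)c2)c1` differs from compound 3 by isopropyl in place of hydroxy on an aromatic carbon. Going by the values given here, the only measured step that bears on this change is a 15-fold higher number from compound 1 to compound 3 (1.18 log units; beyond the scatter), where the hydroxy that compound 4 now loses entered. Taking away that hydroxy is therefore expected to lower the number, but the entering isopropyl has no counterpart in the measured compounds, so the size is uncertain and the expected step of a 4.3-fold lower number from compound 3 to compound 4 (0.63 log units; beyond the scatter) is set smaller than the measured one. Compound 4 is estimated at 15 nM, with a range from 4 nM to 60 nM.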

Compound 4, half-maximal inhibitory concentration: 4 nM
Beside the measured number, compound 4's estimate is 3.8-fold (0.57 log units) above it, and the stated range covers the measured number.
By their numbers in this assay, from the lowest: compounds 4 and 1 (each within the scatter of the next); then compound 2; then compound 3.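

In this assay, isopropyl in place of hydroxy gives a 16-fold lower number from compound 3 to compound 4 (1.20 log units; beyond the scatter), so this position, para to a hydroxy group, carries a group of 3 heavy atoms and 0 hydrogen-bond donors with a far lower number than hydroxy. A low number here therefore does not require the hydroxy. No measurement on hand gives a reason for this step. The compounds shown leave open how much of the step follows the loss of hydroxy and how much the entry of isopropyl. A methyl or an amine at this position would bear on that.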